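The compounds below may be only part of what the source reports. "The series", "measured", "known", "first", "only" and "open" are said of these compounds alone.

Compound 1 `COc1ccc(-c2c(Cl)c(=O)c3c(OC)cc(OC)cc3n2S(=O)(=O)c2ccc(OC)cc2)cc1` and compound 2 `COc1ccc(-c2c(Br)c(=O)c3c(OC)cc(OC)cc3n2S(=O)(=O)c2ccc(OC)cc2)cc1` share one core and differ only in the halogen on it. In a functional assay on KOPN-8 cells (Homo sapiens) for antiproliferative activity, with a stated time of 72 h (a higher number here means that more compound is needed for the effect, a lower number that less compound is needed), compound 1 gives 19100 nM. For the measured compounds named here, compound 2 gives 2580 nM in this assay, and the step of a 7.4-fold lower number from compound 1 to compound 2 (0.87 log units; beyond the scatter) is the only measured step in the set. Compound 3 `COc1ccc(-c2cc(=O)c3c(OC)cc(OC)cc3n2S(=O)(=O)c2ccc(C)c([N+](=O)[O-])c2)cc1` carries no halogen on the core and a 4-methyl-3-nitrophenyl on the sulfonyl sulfur. For compound 3 this assay reports only a limit, > 51700 nM, so compound 3 stands at the limit of > 51700 nM in this assay, at which 1 of the 3 values shown sits, rather than at a number. Compound 4 `COc1ccc(-c2cc(=O)c3c(OC)cc(OC)cc3n2S(=O)(=O)c2c(F)c(F)c(F)c(F)c2F)cc1` differs from compound 3 by 2,3,4,5,6-pentafluorophenyl in place of 4-methyl-3-nitrophenyl on a sulfonyl sulfur. Going by the values given here, no measured step involves this change, so its size and direction cannot be read from the halogen step. Compound 4 is therefore expected to stay weak, near 40000 nM with a range of 8000 nM to 150000 nM. This expectation amounts to a step of an at least 1.2-fold lower number from compound 3 to compound 4 (0.11 log units; that floor lies within the scatter).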

Compound 4, half-maximal effective concentration: > 34400 nM
Compound 4 gave a limit, no number; the forecaster's own chance of this, stated with the estimate: 55%; the middle value is on the limit's open side.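

Compound 3 and compound 4 both give only limits in this assay, so the step between them cannot be read. Which of 4-methyl-3-nitrophenyl and 2,3,4,5,6-pentafluorophenyl on the sulfonyl sulfur needs less compound remains open.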